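Swapping a Thiazole for Chlorophenyl: Stability Expectation

The source may report more compounds than this note shows. Statements on the series, on what has been measured and on what is new or still open speak of the compounds shown alone.

Compound 1, `CCOC(=O)C1c2c[nH]nc2CCN1S(=O)(=O)c1ccc(Cl)cc1`: 1%
Compound 2, `O=S(=O)(c1ccc(Cl)cc1)N1Cc2c[nH]nc2CC1c1nccs1`: 8%
Compound 3, `CC[C@@H]1c2c[nH]nc2C[C@H](c2ccc(Cl)cc2)N1S(=O)(=O)c1ccc(Cl)cc1`: 25%

These three compounds share a common core and were tested in an ADME assay on microsomes from liver (Homo sapiens) for metabolic stability, with a stated time of 30 min, in the presence of a further agent that is not named here; a lower number here means that less of the compound is left, a higher number that more of the compound is left. Compound 2 gives 8%, the second highest of the three numbers; its gap to compound 1 lies within the usual scatter, while compound 3 sits beyond the scatter with the higher value. Compound 4, `O=S(=O)(c1ccc(Cl)cc1)N1Cc2c[nH]nc2CC1c1ccc(Cl)cc1`, is not yet measured. It differs from compound 2 in one place: 4-chlorophenyl in place of 1,3-thiazol-2-yl on a saturated ring carbon. Within the data shown here, no measured pair isolates this change, but compound 3, which also carries a 4-chlorophenyl on a saturated ring carbon, reaches 25%. A modest rise beyond the scatter is therefore expected, a step of a number 8 percentage points higher from compound 2 to compound 4 (within the scatter). Compound 4 is estimated at 16%, with a range from 5% to 30%.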

Compound 4, percent of the compound remaining: 33%
The estimate for compound 4 lay 17 percentage points below the measured number; the measured number lies above the stated range.
By their numbers in this assay, from the lowest: compounds 1 and 2 (each within the scatter of the next); then compounds 3 and 4 (each within the scatter of the next).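

In this assay there is a number 25 percentage points higher from compound 2 to compound 4 (beyond the scatter) when 4-chlorophenyl replaces 1,3-thiazol-2-yl on this saturated ring carbon. Among these compounds, this is the first pair differing in one place, and it shows that the number in this test responds to the group held at this position. No measurement shown bears on why the number rises.

As far as these compounds go, whether the step goes with the chlorine or with the six-membered carbon ring stays open. An unsubstituted phenyl on this carbon would tell the two apart.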